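Acetoxy to acetamido on the sugar ring, tried twice

The compounds below may be only part of what the source reports. "The series", "measured", "known", "first", "only" and "open" are said of these compounds alone.

Three compounds have been measured in a functional assay on MDA-MB-231 cells (Homo sapiens) for cytotoxicity, read by sulforhodamine B assay, with a stated time of 72 h; a higher number here means a weaker inhibitor, a lower number a stronger inhibitor:

compound 1 `CC(=O)OC[C@H]1O[C@@H](OC2=CC(=O)c3ccccc3C2=O)[C@H](OC(C)=O)[C@@H](OC(C)=O)[C@@H]1OC(C)=O` gives 12600 nM
compound 2 `CC(=O)N[C@H]1[C@H](OC2=CC(=O)c3ccccc3C2=O)O[C@H](COC(C)=O)[C@@H](OC(C)=O)[C@@H]1OC(C)=O` gives 27600 nM
compound 3 `CC(=O)OC[C@H]1O[C@@H](n2cc(COC3=CC(=O)c4ccccc4C3=O)nn2)[C@H](OC(C)=O)[C@@H](OC(C)=O)[C@@H]1OC(C)=O` gives 14000 nM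

Compound 1 and compound 2 share a core and differ in one place, (acetamido in place of acetoxy on a saturated ring carbon). That change made a 2.2-fold higher number from compound 1 to compound 2 (0.34 log units; beyond the scatter). Compound 3 carries a different core; how the cores of compound 1 and compound 3 differ is not broken down here. The values of compound 3 and compound 1 lie within the scatter of each other, and so do those of compound 3 and compound 2.

Compound 4 `CC(=O)N[C@@H]1[C@@H](OC(C)=O)[C@H](OC(C)=O)[C@@H](COC(C)=O)O[C@H]1n1cc(COC2=CC(=O)c3ccccc3C2=O)nn1` has not been measured. It differs from compound 3 by acetamido in place of acetoxy on a saturated ring carbon. The surroundings of the changed carbon are described in the same words for both pairs, so this is the same change, now on the core of compound 3. Within the data shown here, the one earlier example of this change, the step from compound 1 to compound 2, is the only guide. Compound 4 is therefore expected to show a 2.0-fold higher number from compound 3 to compound 4 (0.30 log units; within the scatter) in this assay, because the earlier step was a 2.2-fold higher number from compound 1 to compound 2 (0.34 log units; beyond the scatter). Compound 4 is estimated at 28000 nM, with a likely range from 14000 nM to 60000 nM.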

Compound 4, half-maximal inhibitory concentration: > 50000 nM
Compound 4: a limit, no number; the forecaster's own chance of this, stated with the estimate: 15%; middle value at least 1.7-fold (0.25 log units) away from the limit.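

In this assay compound 4 gives > 50000 nM, which is a limit of the assay and not a number. The step can still be read as a minimum, and placing acetamido where acetoxy stood gives an at least 3.5-fold higher number from compound 3 to compound 4 (0.55 log units; beyond the scatter). This shows the change pushing the number the same way on both cores, towards a weaker inhibitor, but two pairs are few, and the data do not show whether its size carries over from one core to the other: the same change on two cores in this assay, a 2.2-fold higher number (0.34 log units; beyond the scatter) from compound 1 to compound 2 and an at least 3.5-fold higher number (0.55 log units; beyond the scatter) from compound 3 to compound 4; the limit leaves it open whether they differ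

The compounds shown leave open what other groups on this saturated ring carbon would do, such as a free hydroxyl, an amine or a longer amide like propionamido. They also leave open whether the same direction would hold on a third core, or if one of the other acetoxy groups on the ring were exchanged for a free hydroxyl or an amine.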